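Oxygen for sulfur in a side ring on two cores

The source may hold more compounds than are shown below. What is called first, only, known or untested is meant among the compounds shown, and "the series" means these compounds.

Measured compounds:
Compound 1, `Cc1ccc(C2CNN=C2S(=O)(=O)CC2=NCCS2)cc1`, with 48.6%
Compound 2, `Cc1ccc(-c2c[nH]nc2S(=O)(=O)CC2=NCCS2)cc1`, with "not active" (no number reported)
Compound 3, `Cc1ccc(C2CNN=C2S(=O)(=O)CC2=NCCO2)cc1`, with 49.7%

In a functional assay, read by Griess assay, with a stated time of 150 min, tested at 75 ug/mL (a lower number here means a weaker effect, a higher number a stronger effect of the compound at the concentration tested), compound 1 gives 48.6%. Compound 3 carries a group of 5 heavy atoms (3 carbon, 1 nitrogen, 1 oxygen; one five-membered non-aromatic ring with 2 hetero atoms) in place of a group of 5 heavy atoms (3 carbon, 1 nitrogen, 1 sulfur; one five-membered non-aromatic ring with 2 hetero atoms), on a saturated chain carbon bound to a sulfonyl sulfur, and in this assay compound 3 gives 49.7%. The step is a number 1.1 percentage points higher from compound 1 to compound 3 (within the scatter), so the exchange of the sulfur ring for the oxygen ring leaves the read-out where it was on this core.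

Compound 2 has a different core from compound 1; how the two cores differ is not broken down here. In this assay compound 2 gives "not active" (no number reported), and no number was reported for it.

Compound 4, `Cc1ccc(-c2c[nH]nc2S(=O)(=O)CC2=NCCO2)cc1`, has not yet been measured in this assay. It differs from compound 2 by a group of 5 heavy atoms (3 carbon, 1 nitrogen, 1 oxygen; one five-membered non-aromatic ring with 2 hetero atoms) in place of a group of 5 heavy atoms (3 carbon, 1 nitrogen, 1 sulfur; one five-membered non-aromatic ring with 2 hetero atoms), on a saturated chain carbon bound to a sulfonyl sulfur, the same change that leads from compound 1 to compound 3 and at the same place. Among the compounds with values here, that change made a step within the scatter from compound 1 to compound 3, so on the core of compound 2 it is expected to make a step of about the same size, which is to say no real step. Since compound 2 gave no number in this assay, compound 4 is expected to stay weak as well and may again be reported only as not active. Compound 4 is expected to give about 10% in this assay, with a range from 0% to 30%.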

Compound 4, a percentage reported as activity, at one concentration (the size of the read-out at that concentration, not a potency): 63.5%
For compound 4 the middle estimate is 53.5 percentage points below the measured one, outside the stated range (above it).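

In this assay, within the data shown here, compound 4 gives 63.5% but compound 2 has no number, so no step between compound 2 and compound 4 can be read. The compounds shown leave open whether the oxygen ring in place of the sulfur ring has the same size of effect on the core of compound 2 as on the core of compound 1. No measurement shown here bears on the result for compound 4.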